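The compounds below may be only part of what the source reports. "The series", "measured", "known", "first", "only" and "open" are said of these compounds alone.

Among the compounds with values here, compound 3 `Cc1n[nH]c(C(=O)O)c1Cc1cccc(-c2ccccc2F)c1` gives 900 nM in an assay on isolated protein for inhibition of 2-Hydroxyacid oxidase 2 (Rattus norvegicus) (on this read-out lower numbers stand for stronger inhibition and higher numbers for weaker inhibition), the highest of the three numbers measured so far. Compound 1 `Cc1n[nH]c(C(=O)O)c1Cc1cccc(-c2cccc(F)c2)c1` gives 500 nM and compound 2 `Cc1n[nH]c(C(=O)O)c1Cc1cccc(-c2ccc(C#N)cc2)c1` gives 300 nM; the step of a 1.8-fold higher number from compound 1 to compound 3 (0.26 log units; within the scatter) stays within the scatter, whereas a 3.0-fold higher number from compound 2 to compound 3 (0.48 log units; beyond the scatter) lies beyond it. Compound 4 `Cc1n[nH]c(C(=O)O)c1Cc1cccc(C(N)=O)c1` differs from compound 3 by carbamoyl in place of 2-fluorophenyl on an aromatic carbon. Within the data shown here, no measured step bears directly on this change: the steps of a 1.7-fold lower number from compound 1 to compound 2 (0.22 log units; within the scatter) and a 1.8-fold higher number from compound 1 to compound 3 (0.26 log units; within the scatter) only exchange one aryl group for another, and all three stay small to modest, while the present change removes the ring altogether. The expected step in this assay is therefore uncertain, and a wider range than the measured steps is appropriate. For compound 4 the estimated value is 3000 nM, with a range from 700 nM to 15000 nM. This estimate means an expected step of a 3.3-fold higher number from compound 3 to compound 4 (0.52 log units; beyond the scatter).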

Compound 4, half-maximal inhibitory concentration: 900 nM
The estimate for compound 4 lay 3.3-fold (0.52 log units) above the measured number, and the stated range covers the measured number.
By their numbers in this assay, from the lowest: compounds 2, 1, 3 and 4 (each within the scatter of the next, the first and the last beyond it).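

Replacing the whole ring with carbamoyl on this aromatic carbon still gives no change at the digits printed from compound 3 to compound 4 (within the scatter) and a 1.8-fold higher number from compound 1 to compound 4 (0.26 log units; within the scatter), so in these compounds an aryl group is not needed here for a number in this range. Only 4-cyanophenyl stands apart from carbamoyl, with a 3.0-fold higher number from compound 2 to compound 4 (0.48 log units; beyond the scatter), which makes that aryl group the one substituent here with a step beyond the scatter against carbamoyl. Nothing measured here accounts for this result.

Open, on these data alone, is whether a nitrile, an amine or a carboxylic acid attached directly at this carbon would match carbamoyl. Also open, as far as these compounds go, is how a longer chain ending in carbamoyl would compare.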